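The source may hold more compounds than are shown below. What is called first, only, known or untested is meant among the compounds shown, and "the series" means these compounds.

Measured so far:
- compound 1 `CC(C)C[C@H](NC(=O)N1CCOCC1)C(=O)N[C@H](C)CCc1ccccc1` — a limit only, > 339000 nM
- compound 2 `CC(C)C[C@H](NC(=O)N1CCOCC1)C(=O)NCC#N` — 124 nM

In an assay for inhibition of cathepsin S (Homo sapiens) (on this read-out lower numbers stand for stronger inhibition and higher numbers for weaker inhibition), compound 2 gives 124 nM, the only numerical result in the set. The value for compound 1 is a limit of the assay, not a number (the limit of > 339000 nM in this assay, at which 1 of the 2 values shown sits). Compound 3 `CC(C)C[C@H](NC(=O)N1CCOCC1)C(=O)N[C@H](C#N)COCc1ccccc1Cl` differs from compound 2 by ((2-chlorobenzyl)oxy)methyl in place of hydrogen on a saturated chain carbon bound to an amide-type nitrogen and a triple-bonded carbon. For the measured compounds named here, no measured pair differs in one place, so no step size is known. The step from compound 2 to compound 3 is expected to be a 16-fold lower number from compound 2 to compound 3 (1.19 log units; beyond the scatter), toward stronger inhibition and beyond the scatter. Compound 3 is estimated at 8 nM, between 1.5 nM and 40 nM.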

Compound 3, half-maximal inhibitory concentration: 9 nM
Estimate against measurement, compound 3: 1.1-fold (0.05 log units) below; low and high end bracket the measured number.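

In this assay, for the compounds shown here, the saturated chain carbon bound to an amide-type nitrogen and a triple-bonded carbon tolerates a large substituent: ((2-chlorobenzyl)oxy)methyl in place of hydrogen gives a 14-fold lower number from compound 2 to compound 3 (1.14 log units; beyond the scatter) as the first readable step. Substitution at this position therefore strengthens inhibition rather than abolishing it, at least for this group. No measurement shown accounts for the gain. As far as these compounds go, it remains open how much of the step depends on the chlorine, and whether a plain methyl or an amine at this carbon would give a similar step.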